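Swapping Chloro for Amino in a Small Series

The source may report more compounds than this note shows. Statements on the series, on what has been measured and on what is new or still open speak of the compounds shown alone.

In a physicochemical assay for lipophilicity, measured as octanol-water partition (on this read-out lower numbers stand for lower lipophilicity and higher numbers for higher lipophilicity), compound 1 `Cc1c(CN2CCCC2)cc(-c2ccccc2)n1Nc1ccnc2cc(Cl)ccc12` gives 4.6, compound 2 `Cc1c(CN2CCCC2)cc(-c2ccc(Cl)cc2)n1Nc1ccnc2cc(Cl)ccc12` gives 5.17 and compound 3 `Cc1c(CN2CCCC2)cc(-c2ccc(C(F)(F)F)cc2)n1Nc1ccnc2cc(Cl)ccc12` gives 5.28. Compound 2 thus lies within the scatter of compound 3 and clearly above compound 1. Compound 4 `Cc1c(CN2CCCC2)cc(-c2ccc(N)cc2)n1Nc1ccnc2cc(Cl)ccc12` differs from compound 2 in one place: amino in place of chloro on an aromatic carbon. For the measured compounds named here, no measured step involves amino. The closest guides are the modest a number 0.57 log units higher from compound 1 to compound 2 (beyond the scatter) and the modest a number 0.68 log units higher from compound 1 to compound 3 (beyond the scatter), while a number 0.11 log units higher from compound 2 to compound 3 (within the scatter) stays within the scatter. Removing chloro would be expected to reverse at least the first of these, so a downward move beyond the scatter is expected, estimated as a number 1.17 log units lower from compound 2 to compound 4 (beyond the scatter). Compound 4 is estimated at 4, with an expected range from 3.5 to 4.5.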

Compound 4, partition coefficient: 4.38
The estimate for compound 4 lay 0.38 log units below the measured number, and the stated range covers the measured number.
By their numbers in this assay, from the lowest: compounds 4 and 1 (each within the scatter of the next); then compounds 2 and 3 (each within the scatter of the next).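

With amino on this aromatic carbon, para to a large group, the number in this assay stays within the scatter of the unsubstituted compound (a number 0.22 log units lower from compound 1 to compound 4 (within the scatter)). Chloro and trifluoromethyl do not stay within it, and amino falls clearly short of both (a number 0.79 log units lower from compound 2 to compound 4 (beyond the scatter); a number 0.90 log units lower from compound 3 to compound 4 (beyond the scatter)). No measurement shown here explains this difference. On these data alone, whether other groups, such as hydroxyl or a carboxylic acid, would also match compound 1 stays open. So does whether a dimethylamino group would behave like amino.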